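From benzyl to 4-methylbenzyl at the assay limit

The source may report more compounds than this note shows. Statements on the series, on what has been measured and on what is new or still open speak of the compounds shown alone.

Compound 1 `COc1ccc(C(OCc2ccccc2)c2cccc3ccccc23)c(OC)c1OC` gives > 20000 nM (a limit)
Compound 2 `CCOC(=O)/C=C/CO/N=C(/c1ccc(OC)c(OC)c1OC)c1cccc2ccccc12` gives > 20000 nM (a limit)
Compound 3 `COc1ccc(C(O)(C/C=C\c2ccccc2)c2cccc3ccccc23)c(OC)c1OC` gives > 20000 nM (a limit)

In a functional assay on HCT-116 cells (Homo sapiens) for inhibition, read by sulforhodamine B assay, with a stated time of 48 h (a higher number here means a weaker inhibitor, a lower number a stronger inhibitor), compound 1 gives > 20000 nM as a limit of the assay and not a number. Within the data shown here, compound 2 and compound 3 offer no firmer reading, so the whole set rests on the limit of > 20000 nM in this assay, at which 3 of the 3 values shown sit, and no step between measured compounds is available as a guide.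

Compound 4 `COc1ccc(C(OCc2ccc(C)cc2)c2cccc3ccccc23)c(OC)c1OC` keeps the core of compound 1 and changes it in one place, with methyl in place of hydrogen on an aromatic carbon, para to a large group. This turns benzyloxy into (4-methylbenzyl)oxy, and the difference counts as methyl in place of hydrogen on an aromatic carbon in full.

Given that compound 1 stands at > 20000 nM in this assay and the change is a single methyl, compound 4 is expected to be reported as a limit as well. The expected change, a number no higher from compound 1 to compound 4 (the limit leaves the size open), is estimated to lie within the scatter, in neither direction. For compound 4 the estimate is 20000 nM, with an expected range of 8000 nM to 40000 nM.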

Compound 4, half-maximal inhibitory concentration: > 20000 nM
Compound 4: a limit, no number; the forecaster's own chance of this, stated with the estimate: 75%; the middle value lies on the limit itself.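

In this assay, among these compounds, compound 4 is reported as a limit and not a number, as is compound 1, so no step between compound 1 and compound 4 can be read. The compounds shown leave open what separates these structures in potency, since all rest on one reading: the limit of > 20000 nM in this assay, at which 4 of the 4 values shown sit.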